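The source may hold more compounds than are shown below. What is called first, only, known or untested is meant among the compounds shown, and "the series" means these compounds.

Measured compounds:
compound 1, `O=C(/C=C/c1ccc(N2CCCC2)cc1)c1ccc(O)cc1`, 60%
compound 2, `COc1cc(O)ccc1C(=O)/C=C/c1ccc(F)cc1`, 61.6%
compound 3, `O=C(/C=C/c1ccc(N2CCCC2)cc1)c1ccc(F)cc1`, 73.1%

In an assay on isolated protein for inhibition of DNA topoisomerase 1 (Homo sapiens), tested at 20 uM (a lower number here means a weaker effect, a higher number a stronger effect of the compound at the concentration tested), compound 1 gives the lowest of the three numbers. Compound 2 lies within the scatter of it, so no order between those two can be read. Compound 3 stands clearly apart: a number 13.1 percentage points higher from compound 1 to compound 3 (beyond the scatter). Among the measured compounds shown here, that one step is the only change of a single place in this set, and it swaps one group for another.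

Compound 4, `O=C(/C=C/c1ccc(N2CCCC2)cc1)c1ccc(O)cc1O`, is not yet measured. It differs from compound 1 in one place: hydroxy in place of hydrogen on an aromatic carbon. The new group sits on an aromatic carbon of a six-membered aromatic ring of carbon only, ortho to a large group and meta to a hydroxy group that is already present.

For the measured compounds named here, no measured step adds a group where a hydrogen stood, so nothing here speaks directly to this change. The hydroxy-to-fluoro swap from compound 1 to compound 3 tells how one group compares to another, not what a second hydroxy does. With nothing to lean on, the expectation is that the number stays within the scatter of compound 1, and the estimated step is no change at the digits printed from compound 1 to compound 4 (within the scatter). Compound 4 is therefore estimated at 60%, with a range from 45% to 75%.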

Compound 4, a percentage reported as inhibition, at one concentration (the size of the read-out at that concentration, not a potency): 64.4%
Compound 4: middle estimate off by 4.4 percentage points, on the low side, within the range that was stated.
By their numbers in this assay, from the lowest: compounds 1, 2, 4 and 3 (each within the scatter of the next, the first and the last beyond it).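

In this assay the result is a number 4.4 percentage points higher from compound 1 to compound 4 (within the scatter) when a hydroxy replaces hydrogen on this aromatic carbon, ortho to a large group and meta to the hydroxy already present. Among the compounds shown here, this is the first step in the set that adds a group where a hydrogen stood, and it shows that the core of compound 1 can carry this second hydroxy without a readable shift in the read-out at the one concentration tested. No supporting measurement bears on why the read-out behaves this way.

From the compounds shown here alone, whether a larger or differently built group, such as an amine or a carboxylic acid, would also leave the read-out unmoved on this carbon remains open. So does the question of whether a hydroxy on another carbon of the same ring would behave like this one.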